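The compounds below may be only part of what the source reports. "The series", "measured", "known", "first", "only" and "open" are said of these compounds alone.

Working notes on the series. Of the compounds shown here, two have numbers so far in an assay on HEK293 cells for displacement of a labelled ligand from NPC1-like intracellular cholesterol transporter 1 (Homo sapiens); on this read-out lower numbers stand for stronger inhibition and higher numbers for weaker inhibition. Compound 1, `CC(C)(C)OC(=O)NCC1CCCN(C(=O)CN2CN(c3ccccc3)C3(CCN(C(=O)c4ccc(C5CCCCC5)cc4)CC3)C2=O)C1`, gives 3800 nM in this assay. Compound 2, `O=C(CN1CN(c2ccccc2)C2(CCN(C(=O)c3ccc(C4CCCCC4)cc3)CC2)C1=O)NCCCCO`, gives 10300 nM in this assay, the higher of the two numbers; the gap between the values of compound 2 and compound 1 lies beyond the usual scatter, so compound 2 is the weaker of the pair. Among the measured compounds shown here, no single-point step between measured compounds exists in this set, so the only guide for a new change is the pair of values themselves and the change itself.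

Compound 3, `COC(=O)CCCNC(=O)CN1CN(c2ccccc2)C2(CCN(C(=O)c3ccc(C4CCCCC4)cc3)CC2)C1=O`, differs from compound 2 by methoxycarbonyl in place of hydroxymethyl on a saturated chain carbon, three bonds along the chain from an amide-type nitrogen. The chain is otherwise unchanged, and the shared core of compound 2 is kept intact. For the measured compounds named here, nothing among the measured compounds shows how this assay responds to such a swap at the chain end, so no direction is supported by the data, and a step no larger than the usual scatter is the default expectation.

Compound 3 is therefore expected to give 9000 nM in this assay, within 3000 nM to 30000 nM. The expected step is a 1.1-fold lower number from compound 2 to compound 3 (0.06 log units; within the scatter).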

Compound 3, half-maximal inhibitory concentration: 2500 nM
Compound 3: middle estimate off by 3.6-fold (0.56 log units), on the high side; the measured number lies below the stated range.
By their numbers in this assay, from the lowest: compounds 3 and 1 (each within the scatter of the next); then compound 2.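

In this assay the chain end turns out to respond to a single change: the step is a 4.1-fold lower number from compound 2 to compound 3 (0.61 log units; beyond the scatter) when methoxycarbonyl stands in place of hydroxymethyl on a saturated chain carbon, three bonds along the chain from an amide-type nitrogen. With the shared core kept intact, this position is therefore not silent, and going from 4-hydroxybutyl to 3-(methoxycarbonyl)propyl gives a lower number even though the hydrogen-bond donor of the leaving group is lost and heavy atoms are gained. Nothing at hand explains the step, and this one pair cannot tell apart the loss of the donor, the added acceptor and the larger group.

The compounds shown leave open whether the gain belongs to methoxycarbonyl itself or would also appear with a carboxylic acid, a primary amide or a methoxy group at the chain end. They also leave open how a longer or shorter chain carrying the same methoxycarbonyl would read on this assay, since the chain length is the same in both compounds of the pair.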